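Cytotoxicity limit in the series and a hexylsulfanyl change

The source may hold more compounds than are shown below. What is called first, only, known or untested is meant among the compounds shown, and "the series" means these compounds.

Compound 1 `Nc1nc(NCc2ccccc2)c2ncn(/C=C3/CC3(CO)CO)c2n1`: > 300000 nM
Compound 2 `Nc1nc(NC2CCCCC2)c2ncn(/C=C3/CC3(CO)CO)c2n1`: > 300000 nM

In an ADME assay on HFF cells (Homo sapiens) for cytotoxicity, with a stated time of 8 days (a higher number here means that more compound is tolerated, a lower number that less compound is tolerated), compound 2 stands at > 300000 nM, which is a limit and not a number. Compound 1 gives > 300000 nM, which is also a limit. Together they make up (the limit of > 300000 nM in this assay, at which 2 of the 2 values shown sit). For the measured compounds named here, the only measured step is a step that the two limits leave unreadable from compound 1 to compound 2, so the series offers no readable step size.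

Compound 3 `CCCCCCSc1nc(N)nc2c1ncn2/C=C1/CC1(CO)CO` differs from compound 2 as follows: hexylsulfanyl in place of cyclohexylamino on an aromatic carbon. Going by the values given here, no measured compound carries hexylsulfanyl, and the measured step concerns only the group on the nitrogen, so it bears on this change weakly. In this assay a readable step can only run towards less compound tolerated, given that compound 2 sits at the limit of > 300000 nM. The expected outcome is a modest move in that direction, estimated as an at least 2.0-fold lower number from compound 2 to compound 3 (0.30 log units; that floor lies within the scatter). Staying at the limit is about as likely as giving a number. Compound 3 is estimated at 150000 nM. The expected range for compound 3 runs from 40000 nM to 300000 nM.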

Compound 3, half-maximal cytotoxic concentration: > 300000 nM
Compound 3: no number, only a limit; the forecaster's own chance of this, stated with the estimate: 50%; middle value at least 2.0-fold (0.30 log units) away from the limit.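

In this assay compound 3 gives > 300000 nM, which is a limit and not a number. For the compounds shown here, no step among compound 1, compound 2 and compound 3 can be read: the limit of > 300000 nM in this assay, at which 3 of the 3 values shown sit.

Left open is whether hexylsulfanyl, cyclohexylamino and benzylamino differ at all in how much compound is tolerated.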